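Swapping a Dimethylamino for a Piperidine Ring

This account rests on a few compounds, and the source may have more. Where it says the series, first, only, none or still open, it means among the compounds named here.

Three compounds have been measured in an assay on HeLa cells for binding affinity to Vasopressin V2 receptor (Homo sapiens); on this read-out higher numbers stand for weaker inhibition and lower numbers for stronger inhibition:

compound 1 `CN(C)c1ccc(C(=O)N2CCCCc3ccccc32)c(Cl)c1` gives 18 nM
compound 2 `CCNc1ccc(C(=O)N2CCCCc3cc(Cl)ccc32)c(Cl)c1` gives 5 nM
compound 3 `O=C(c1ccc(N2CCCC2)cc1)N1CCCCc2ccccc21` gives 1000 nM

Among these three numbers compound 1 stands second highest. Compound 2 sits clearly lower, a gap beyond the usual scatter, while compound 3 sits far higher, also well beyond the scatter.

Compound 4 `O=C(c1ccc(N2CCCCC2)cc1Cl)N1CCCCc2ccccc21` is the compound not yet measured. It differs from compound 1 in one place: piperidin-1-yl in place of dimethylamino on an aromatic carbon. Going by the values given here, no pair of measured compounds differs by exactly this kind of change, so the size of the step has to be guessed from indirect hints. Compound 3 carries a pyrrolidin-1-yl ring where compound 1 carries its dimethylamino group, and compound 3 also lacks the chloro group; with two differences at once, its much higher number cannot be pinned on the ring amine alone. Still, the only ring amine seen so far goes with a weak result, so a move toward weaker binding is expected, of the size a 5.6-fold higher number from compound 1 to compound 4 (0.74 log units; beyond the scatter). Compound 4 is therefore estimated at 100 nM in this assay, with a range from 20 nM to 600 nM.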

Compound 4, half-maximal inhibitory concentration: 120 nM
For compound 4 the middle estimate is 1.2-fold (0.08 log units) below the measured one, and the stated range covers the measured number.
By their numbers in this assay, from the lowest: compound 2; then compound 1; then compound 4; then compound 3.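

In this assay, going by these compounds alone, the step of a 6.7-fold higher number from compound 1 to compound 4 (0.82 log units; beyond the scatter) gives the first direct reading of a ring amine at this position. The chloro group and the rest of the core stay the same and only the amine changes. At this aromatic carbon, meta to a chloro group and para to a large group, piperidin-1-yl therefore goes with clearly weaker binding than dimethylamino, although compound 4 still gives a measurable 120 nM. No measurement is available that explains the direction or size of this step.

Going by these compounds, it remains open whether a morpholin-4-yl ring or an open-chain diethylamino group would bring a similar loss, which would help show whether the ring itself matters. Also open, on these data alone, is whether the same swap would cost as much on the core of compound 2, which carries an extra chloro group.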